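The source may report more compounds than this note shows. Statements on the series, on what has been measured and on what is new or still open speak of the compounds shown alone.

Measured compounds:
compound 1 `O=C1CSC(c2ccc(Cl)cc2)N1n1c(CSc2nnc(-c3ccncc3)o2)nc2ccc(Br)cc2c1=O` — 25.2%
compound 2 `O=c1c2cc(Br)ccc2nc(CSc2nnc(-c3ccncc3)o2)n1/N=C/c1ccc(O)cc1` — 22.3%
compound 3 `O=C1CSC(c2ccc(O)cc2)N1n1c(CSc2nnc(-c3ccncc3)o2)nc2ccc(Br)cc2c1=O` — 32.7%

In a functional assay on the whole organism (strain Charles-Foster albino) for inhibition, with Rattus norvegicus as the target, read by paw edema, at a dose of 50 mg/kg by the oral route (a lower number here means less inhibition, a higher number more inhibition at the dose given (going by the name of the read-out)), compound 3 gives 32.7%, compound 1 gives 25.2% and compound 2 gives 22.3%. Compound 2 and compound 1 lie within the scatter of each other; compound 3 stands beyond the scatter above compound 2. The change from compound 3 to compound 1 chloro in place of hydroxy on an aromatic carbon made a step of a number 7.5 percentage points lower from compound 3 to compound 1 (within the scatter). Compound 4 `O=c1c2cc(Br)ccc2nc(CSc2nnc(-c3ccncc3)o2)n1/N=C/c1ccc(Cl)cc1` is not yet measured. The difference between the cores of compound 2 and compound 3 is not broken down here. The change from compound 2 to compound 4 chloro in place of hydroxy on an aromatic carbon is the same change at the same kind of place. In this assay, for the measured compounds named here, the step from compound 2 to compound 4 is expected to be a number 5.3 percentage points lower from compound 2 to compound 4 (within the scatter), resting on the single measured instance a number 7.5 percentage points lower from compound 3 to compound 1 (within the scatter) on the other core. Compound 4 is accordingly estimated at 17%, expected to fall between 9% and 26%.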

Compound 4, a percentage reported as inhibition, in the whole organism at one dose (the size of the read-out at that dose, not a potency): 26.4%
For compound 4 the middle estimate is 9.4 percentage points below the measured one; the measured number lies above the stated range.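

In this assay the change from 4-hydroxyphenyl to 4-chlorophenyl gives a step of a number 4.1 percentage points higher from compound 2 to compound 4 (within the scatter). Set beside the earlier step, the opposite directions carry no weight, as the two steps do not differ beyond what repeated measurement allows: the same change on two cores in this assay, a number 7.5 percentage points lower (within the scatter) from compound 3 to compound 1 and a number 4.1 percentage points higher (within the scatter) from compound 2 to compound 4, 11.6 percentage points apart, within the scatter of two such steps With both steps inside the scatter, the two cores show neither a step that carries over with a fixed size or direction nor a real dependence on the core.

Still open, as far as these compounds go, is whether an amine or a carboxylic acid, in place of hydroxy and chloro on that aromatic carbon, would give a step beyond the scatter. Two cores also cannot settle how far any such step would carry across the series.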